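The source may hold more compounds than are shown below. What is called first, only, known or untested is meant among the compounds shown, and "the series" means these compounds.

Working notes on the series.

Compound 1 `Cc1ccc(-c2ccc(NC(=O)c3ccccc3)nc2)cc1` gives 51% in an assay on isolated protein (Aquatica lateralis) for inhibition of Luciferin 4-monooxygenase (Luciola lateralis), read by a luciferase reporter, tested at 10 uM (a lower number here means less inhibition, a higher number more inhibition at the concentration tested (going by the name of the read-out)), the highest of the two numbers recorded so far. For the measured compounds named here, its nearest neighbour is compound 2 `O=C(Nc1ccc(-c2cccc(Cl)c2)cn1)c1ccccc1`, which gives 38% in this assay; the one step measured, a number 13 percentage points lower from compound 1 to compound 2 (beyond the scatter), goes with 3-chlorophenyl in place of 4-methylphenyl on an aromatic carbon.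

Compound 3 `CC(C)(C)c1ccc(-c2ccc(NC(=O)c3ccccc3)nc2)cc1` is not yet measured. It differs from compound 1 as follows: tert-butyl in place of methyl on an aromatic carbon. Going by the values given here, the change sits on the aromatic carbon para to a large group, and no measured step touches this position; the only step on record concerns a different exchange, so it does not bear directly on the present one. With nothing in the series to show that the tert-butyl group moves the read-out in either direction, the expectation is a step within the usual scatter, that is an estimated a number 3 percentage points lower from compound 1 to compound 3 (within the scatter). Compound 3 is therefore expected to give about 48% in this assay, within a range of 30% to 66%.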

Compound 3, a percentage reported as inhibition, at one concentration (the size of the read-out at that concentration, not a potency): 49%
Compound 3: the middle estimate sits 1 percentage points below what was measured; the range from low to high includes it.
By their numbers in this assay, from the lowest: compound 2; then compounds 3 and 1 (each within the scatter of the next).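

For the compounds shown here, the exchange of methyl (1 heavy atom) for tert-butyl (4 heavy atoms), on the aromatic carbon para to a large group, gives the first measured step at this position: in this assay, a number 2 percentage points lower from compound 1 to compound 3 (within the scatter). The read-out therefore stays level across this increase in size, with neither group counting any hydrogen-bond donors or acceptors, and this exchange does not bring the drop seen in the other listed step, a number 13 percentage points lower from compound 1 to compound 2 (beyond the scatter), where 3-chlorophenyl replaces 4-methylphenyl. No measurement in hand accounts for the level read-out at this position, so the finding stands as an observation on this one pair only.

Still open, from the compounds shown here alone, is whether an amine or a carboxylic acid on this same aromatic carbon would leave the read-out level as well, since methyl and tert-butyl are both groups of carbon only and say nothing about groups that count hydrogen-bond donors or acceptors. Also open, going by these compounds, is whether the lower number of compound 2 goes with the chlorine atom or with the different place of the group on the ring, as that step changes both at once.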